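Trading a methyl ether end for an alkene end

This account rests on a few compounds, and the source may have more. Where it says the series, first, only, none or still open, it means among the compounds named here.

This series consists of long-chain dienoate esters that share one core and differ at two ends. Compound 1 `CCOC(=O)/C=C(C)/C=C/CC(C)CCCC(C)(C)OC` carries an ethyl group on the ester oxygen and a 1-methoxy-1-methylethyl group at the far end of the chain. In a physicochemical assay for lipophilicity (on this read-out higher numbers stand for higher lipophilicity and lower numbers for lower lipophilicity), compound 1 gives 5.54. Compound 2 `COC(C)(C)CCCC(C)C/C=C/C(C)=C/C(=O)OC1CC1` gives 5.71, and compound 3 `COC(C)(C)CCCC(C)C/C=C/C(C)=C/C(=O)OC1CCCC1` gives 7.01. Among these three numbers compound 1 stands lowest: the gap a number 0.17 log units higher from compound 1 to compound 2 (within the scatter) lies within the scatter, whereas a number 1.47 log units higher from compound 1 to compound 3 (beyond the scatter) and a number 1.30 log units higher from compound 2 to compound 3 (beyond the scatter) are both large.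

Compound 4 `C=C(C)CCCC(C)C/C=C/C(C)=C/C(=O)OCC` has not been measured in this assay. It differs from compound 1 only at the far end of the chain: 1-methylethenyl in place of 1-methoxy-1-methylethyl on a saturated chain carbon, five bonds along the chain from a double-bonded chain carbon. None of the three measured steps bear on this change, since each of them alters only the group on the ester oxygen and leaves the chain end untouched. The data therefore give no direct guide, and the expectation rests on the nature of the change itself, in which an oxygen-bearing group leaves and a purely carbon group enters; a rise beyond the scatter is expected. For compound 4 the estimate is 6.4, within a range from 5.8 to 7. This estimate means an expected step of a number 0.86 log units higher from compound 1 to compound 4 (beyond the scatter).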

Compound 4, partition coefficient: 6.19
The estimate for compound 4 lay 0.21 log units above the measured number; measured number inside the range.
By their numbers in this assay, from the lowest: compounds 1 and 2 (each within the scatter of the next); then compound 4; then compound 3.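

In this assay, going by these compounds alone, the far end of the chain proves able to move the number, which the earlier compounds could not show, since they varied only the group on the ester oxygen: with the ethyl ester kept, the step is a number 0.65 log units higher from compound 1 to compound 4 (beyond the scatter). This rise beyond the scatter comes with a swap of 1-methoxy-1-methylethyl, with 5 heavy atoms including 1 oxygen, for 1-methylethenyl, with 3 heavy atoms, all carbon, so the entering group is the one with fewer heavy atoms. The swap removes the oxygen, shortens the group and adds a double bond all at once, and no accompanying measurement separates these changes or explains the rise.

The compounds shown leave open how a saturated 1-methylethyl group or a 1-hydroxy-1-methylethyl group would read at this same place, and either would help to tell the loss of the ether oxygen from the gain of the double bond. Also open, going by these compounds, is whether a step of this size would hold with cyclopentyl rather than ethyl on the ester oxygen.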